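Cytotoxicity notes: methyl on the anilino ring

The source may report more compounds than this note shows. Statements on the series, on what has been measured and on what is new or still open speak of the compounds shown alone.

Compound 3 `CCN(CC)CN1C(=O)/C(=N/NC(=S)Nc2ccccc2)c2ccccc21` stands only at a limit in an ADME assay on HeLa cells (Homo sapiens) for cytotoxicity; on this read-out lower numbers stand for higher toxicity in this test and higher numbers for lower toxicity in this test: compound 3 gives >= 20000 nM, which is a limit of the assay and not a number. Compound 1 `CCN(CC)CN1C(=O)/C(=N/NC(N)=S)c2ccccc21` also sits at a limit, giving > 100000 nM in this assay. Compound 2 `CCN(CC)CN1C(=O)/C(=N/NC(=S)Nc2ccccc2)c2cc(Cl)ccc21` likewise gives >= 20000 nM in this assay, again a limit rather than a number. The step that the two limits leave unreadable from compound 1 to compound 3 (phenyl in place of hydrogen on an amide-type nitrogen) and the step that the two limits leave unreadable from compound 2 to compound 3 (hydrogen in place of chloro on an aromatic carbon) are both unreadable, since the limit of > 100000 nM in this assay, at which 1 of the 3 values shown sits, and the limit of >= 20000 nM in this assay, at which 2 of the 3 values shown sit, hold all three values.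

Compound 4 `CCN(CC)CN1C(=O)/C(=N/NC(=S)Nc2ccc(C)cc2)c2ccccc21` differs from compound 3 by methyl in place of hydrogen on an aromatic carbon. Among the measured compounds shown here, no measured step bears on this change in a readable way; the two steps into compound 3 show only two limits facing each other. The change is small and every value in the series rests at a limit, so in this assay no step beyond the scatter is expected, and compound 4 is expected to return a limit rather than a number. The expected step that the limit leaves unreadable from compound 3 to compound 4 is therefore flat within the scatter. Compound 4 is estimated at 30000 nM, between 15000 nM and 100000 nM.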

Compound 4, minimum cytotoxic concentration: >= 20000 nM
Compound 4 ended at the assay's limit (the forecaster's own chance of this, stated with the estimate: 85%); the middle value lies beyond the limit too.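

In this assay compound 4 gives a limit and not a number, and the steps to it from compound 3 and from compound 1 cannot be read. With all four values at limits, the compounds shown leave open whether methyl in place of hydrogen on the aromatic carbon changes the minimum cytotoxic concentration at all, and by how much.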